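Swapping One Aromatic Group at a Ring Nitrogen

The source may report more compounds than this note shows. Statements on the series, on what has been measured and on what is new or still open speak of the compounds shown alone.

Of the compounds shown here, two sharing one core have so far been tested in a functional assay on CHO cells with adenosine receptor A1 (Homo sapiens) as the target, read by cAMP accumulation and immunoassay, with a stated time of 6 min, tested at 0.01 uM; on this read-out higher numbers stand for a weaker effect at the one concentration tested and lower numbers for a stronger effect. Compound 1 `Nc1scc(CN2CCN(c3ccc(OC(F)(F)F)cc3)CC2)c1C(=O)c1ccc(Cl)cc1` gives 0%, the lowest of the two numbers recorded, and compound 2 `Nc1scc(CN2CCN(c3c(F)cccc3F)CC2)c1C(=O)c1cccc(C(F)(F)F)c1` gives 2.1%. The gap between them lies within the scatter of repeated measurements of this kind, so the two results say the same thing: at the single concentration tested neither shows a detectable effect. Within the data shown here, no pair of measured compounds that differ in only one place is available, so nothing yet shows how a single change moves this read-out.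

Compound 3 `Nc1scc(CN2CCN(c3cc(F)ccc3F)CC2)c1C(=O)c1ccc(Cl)cc1` has not been measured. It differs from compound 1 in one place: 2,5-difluorophenyl in place of 4-(trifluoromethoxy)phenyl on an amine nitrogen in a ring. Because compound 1 gives 0% and compound 2, which also carries a difluorophenyl on that ring nitrogen, gives 2.1%, little room remains for a weaker effect, and no step beyond the scatter is expected in either direction. The expected step is a number 2 percentage points higher from compound 1 to compound 3 (within the scatter). For compound 3 in this assay the estimated value is 2%, with a likely range from -5% to 12%.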

Compound 3, a percentage reported as activity, at one concentration (the size of the read-out at that concentration, not a potency): 3.1%
Compound 3: the middle estimate sits 1.1 percentage points below what was measured; measured number inside the range.
By their numbers in this assay, from the lowest: compounds 1, 2 and 3 (each within the scatter of the next).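

Among these compounds, the first comparison in which only one place changes comes from this assay: putting 2,5-difluorophenyl in place of 4-(trifluoromethoxy)phenyl on the amine nitrogen in the ring gives a number 3.1 percentage points higher from compound 1 to compound 3 (within the scatter), so this read-out does not separate the two groups. The exchange removes the oxygen and the trifluoromethyl part of the old group and moves to a smaller aromatic group with fluorine alone, yet with the rest of compound 1 held fixed, the number stays within the normal spread of repeat measurements. No supporting measurement bears on why the two groups read alike.

Both groups are fluorinated phenyl rings, so the result says nothing about a different kind of group on that ring nitrogen, such as an unsubstituted phenyl, a pyridine ring, a benzyl group or a simple alkyl chain. The reading also comes from one concentration, so it cannot show whether the two compounds would still read alike at higher concentrations, where a difference between them might appear.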